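Replacing the 1,2,3,4-tetrahydroisoquinolin-2-yl group of compound 1

A few compounds are considered here, and "the series" means these few. Any claim that something is new, unique, unknown or untested is made for them only; others in the source may bear on it.

In a functional assay on HL-60 cells (Homo sapiens) for cytotoxicity, read by MTT assay, with a stated time of 72 h (a higher number here means a weaker inhibitor, a lower number a stronger inhibitor), compound 1 `COc1ccc(S(=O)(=O)c2nc3ccccc3nc2N2CCc3ccccc3C2)cc1` gives 3690 nM, compound 2 `O=S(=O)(c1ccc(Br)cc1)c1nc2ccccc2nc1N1CCc2ccccc2C1` gives 2610 nM and compound 3 `O=S(=O)(c1ccc(F)cc1)c1nc2ccccc2nc1N1CCc2ccccc2C1` gives 4080 nM, so compound 1 stands within the scatter of both others. Compound 4 `COc1ccc(S(=O)(=O)c2nc3ccccc3nc2N2CCC(O)CC2)cc1` differs from compound 1 elsewhere: 4-hydroxypiperidin-1-yl in place of 1,2,3,4-tetrahydroisoquinolin-2-yl on an aromatic carbon. The measured steps, a 1.4-fold lower number from compound 1 to compound 2 (0.15 log units; within the scatter), a 1.1-fold higher number from compound 1 to compound 3 (0.04 log units; within the scatter) and a 1.6-fold higher number from compound 2 to compound 3 (0.19 log units; within the scatter), all stay within the scatter, but each exchanges only methoxy, bromo or fluoro, so none touches this position. The expectation is therefore loose. A moderate step is expected in this assay, estimated as a 2.2-fold higher number from compound 1 to compound 4 (0.34 log units; beyond the scatter). For compound 4 the estimated value is 8000 nM, with an expected range of 2500 nM to 25000 nM.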

Compound 4, half-maximal inhibitory concentration: 3230 nM
Compound 4: middle estimate off by 2.5-fold (0.39 log units), on the high side, within the range that was stated.
By their numbers in this assay, from the lowest: compounds 2, 4, 1 and 3 (each within the scatter of the next).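

Among the compounds shown here, at the position next to the ring nitrogen, which the earlier compounds left untouched, 4-hydroxypiperidin-1-yl in place of 1,2,3,4-tetrahydroisoquinolin-2-yl gives a 1.1-fold lower number from compound 1 to compound 4 (0.06 log units; within the scatter) in this assay. In this pair, the six-membered aromatic ring of carbon only is therefore not needed to keep the number within the scatter, even with a hydrogen-bond donor entering. Nothing available explains why the two groups read alike. From the compounds shown here alone, it remains open whether an amine, a carboxylic acid or a longer chain here would move the number beyond the scatter, and whether the same exchange reads alike with the bromo group of compound 2 or the fluoro group of compound 3.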